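This account rests on a few compounds, and the source may have more. Where it says the series, first, only, none or still open, it means among the compounds named here.

Of the compounds shown here, three have been measured in an assay on cells for positive allosteric modulation of Cystic fibrosis transmembrane conductance regulator variant F508del (Homo sapiens), with stated times of 10 min and 7 s, in the presence of a further agent that is not named here; on this read-out lower numbers stand for an effect already at smaller amounts and higher numbers for an effect only at larger amounts of compound. Compound 1 `Cc1ccc(C(=O)Nc2sc3c(c2C(N)=O)CCOC3)s1` gives 778 nM. Compound 2 `CC1Cc2c(sc(NC(=O)c3ccccc3O)c2C(N)=O)C(C)O1` gives 4 nM. Compound 3 `CC1(C)Cc2c(sc(NC(=O)C3(O)CC3)c2C(N)=O)C(C)(C)O1` gives 23 nM. Among these three numbers compound 3 stands second highest: compound 2 is its nearest neighbour, with a number well below it and beyond the usual scatter, while compound 1 lies furthest away, far above it and likewise beyond the scatter.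

The next compound, compound 4 `Cc1cc(C(=O)Nc2sc3c(c2C(N)=O)CC(C)(C)OC3(C)C)[nH]n1`, shares its core with compound 3 and differs only in the group on the carbonyl carbon: 3-methyl-1H-pyrazol-5-yl in place of 1-hydroxycyclopropyl on a carbonyl carbon. Going by the values given here, no pair of measured compounds shows this same change, so its effect can only be guessed from what the three measured compounds show.

For compound 4 in this assay a step of a 1.5-fold lower number from compound 3 to compound 4 (0.19 log units; within the scatter) is expected, that is a small move towards a lower number, roughly at the edge of the scatter. The estimate for compound 4 is therefore 15 nM, with a range from 4 nM to 60 nM.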

Compound 4, half-maximal effective concentration: 13 nM
Beside the measured number, compound 4's estimate is 1.2-fold (0.06 log units) above it, and the stated range covers the measured number.
By their numbers in this assay, from the lowest: compound 2; then compounds 4 and 3 (each within the scatter of the next); then compound 1.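

In this assay, putting 3-methyl-1H-pyrazol-5-yl in place of 1-hydroxycyclopropyl on a carbonyl carbon gives a 1.8-fold lower number from compound 3 to compound 4 (0.25 log units; within the scatter), so as far as this measurement can tell, the exchange leaves the number unchanged. Going by these compounds alone, this is the first view of this position with the rest of the molecule held the same: a three-membered non-aromatic carbon ring and a five-membered aromatic ring with 2 hetero atoms both fit there, with 4 and 6 heavy atoms in the group. Nothing available gives a reason for this match.

As far as these compounds go, both groups count 1 hydrogen-bond donor and 1 hydrogen-bond acceptor, so it remains open what a group without that donor, such as tert-butyl, would give in this place. Compound 1 and compound 2 differ from these two in more than one place, so they cannot settle how a plain phenyl or a longer chain would behave on the same core.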